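A few compounds are considered here, and "the series" means these few. Any claim that something is new, unique, unknown or untested is made for them only; others in the source may bear on it.

Measured so far:
compound 1 `CCc1nc2c(-c3ccc(Cl)cc3Cl)ccnc2n1C(C)C1CCC1`, 1 nM in an assay for binding affinity to Corticotropin releasing factor receptor (Rattus norvegicus); a lower number here means a stronger inhibitor, a higher number a weaker inhibitor;
compound 2 `CCCC(C)n1c(CC)nc2c(-c3ccc(C(C)(C)O)cc3Cl)ccnc21`, 24 nM in this assay.

Of these two, compound 1 has the lower number, and the gap to compound 2 lies beyond the scatter. The unmeasured compound 3 `CCc1nc2c(-c3ccc(Cl)cc3Cl)ccnc2n1[C@H](CC)C1CC1` differs from compound 1 in one place: 1-cyclopropylpropyl in place of 1-cyclobutylethyl on an aromatic nitrogen. Among the compounds with values here, no step between measured compounds bears on this change, and the two groups share the same atoms. Compound 3 is therefore expected to stay close to compound 1 in this assay, with a step of a 2.0-fold higher number from compound 1 to compound 3 (0.30 log units; within the scatter) that falls within the scatter. The estimate for compound 3 is 2 nM, with a range from 0.5 nM to 8 nM.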

Compound 3, inhibition constant: 0.2 nM
For compound 3 the middle estimate is 10-fold (1.00 log units) above the measured one, and the stated range ends above it.
By their numbers in this assay, from the lowest: compound 3; then compound 1; then compound 2.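

On the aromatic nitrogen, 1-cyclopropylpropyl in place of 1-cyclobutylethyl gives a step of a 5.0-fold lower number from compound 1 to compound 3 (0.70 log units; beyond the scatter) in this assay, beyond the scatter. This shows that the assay separates two groups with the same atoms at this position, which compound 2, differing from compound 1 in more than one place, could not show. Nothing given here accounts for the step.

Ring size, chain length and the defined stereocentre all change together, so which of them matters stays open. A 1-cyclopropylethyl group at this nitrogen would separate ring from chain.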